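The source may report more compounds than this note shows. Statements on the series, on what has been measured and on what is new or still open speak of the compounds shown alone.

Compound 1 has the structure `COc1cc(/C=N/Nc2nc(-c3ccc(Br)cc3)cs2)cc(Br)c1OC`. In an ADME assay on HUVEC cells (Homo sapiens) for inhibition, read by MTT assay, with a stated time of 48 h (on this read-out higher numbers stand for weaker inhibition and lower numbers for stronger inhibition), compound 1 gives > 100000 nM, which is a limit of the measurement rather than a number. Compound 2, `Fc1ccc(/C=N/Nc2nc(-c3ccc(F)c(F)c3)cs2)cc1F`, gives 59700 nM in this assay. Compound 3, `COc1ccccc1-c1csc(N/N=C/c2ccc(F)c(F)c2)n1`, gives > 100000 nM in this assay, again a limit and not a number. Where compound 1 stands is told by the limit of > 100000 nM in this assay, at which 2 of the 3 values shown sit, so nothing sets it apart from its neighbours. For the measured compounds named here, the one step between two measured compounds that differ in a single place is an at least 1.6-fold higher number from compound 2 to compound 3 (0.22 log units; that floor lies within the scatter). Compound 4, `COc1cc(/C=N/Nc2nc(-c3ccc(F)c(F)c3)cs2)cc(Br)c1OC`, has not yet been measured. It differs from compound 1 by 3,4-difluorophenyl in place of 4-bromophenyl on an aromatic carbon. Going by the values given here, the measured step from compound 2 to compound 3 changes the group at the same place, but it starts from 3,4-difluorophenyl rather than arriving at it, so it bears on the new step only loosely, and compound 2, which carries 3,4-difluorophenyl at that place, is the one compound that gives a number at all. The expected step is an at least 1.2-fold lower number from compound 1 to compound 4 (0.09 log units; that floor lies within the scatter), small and possibly none beyond the scatter. Compound 4 is thus estimated at 80000 nM, with a range from 30000 nM to 200000 nM.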

Compound 4, half-maximal inhibitory concentration: > 100000 nM
Compound 4 ended at the assay's limit (the forecaster's own chance of this, stated with the estimate: 50%); middle value at least 1.2-fold (0.09 log units) away from the limit.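

For the compounds shown here, compound 1 and compound 4 both end at a limit of the measurement in this assay, so no step between them can be read. As far as these compounds go, compound 4 thus joins the group that shares this limit: the limit of > 100000 nM in this assay, at which 3 of the 4 values shown sit. Whether 3,4-difluorophenyl in place of 4-bromophenyl changes inhibition on the core of compound 1, and by how much, stays open.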